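The compounds below may be only part of what the source reports. "The series", "measured", "known", "first", "only" and "open" are said of these compounds alone.

Compound 1 `CN(c1ccccc1)S(=O)(=O)C1CC2OC1C(c1ccc(NC(=O)CCCCCCC(=O)O)cc1)=C2c1ccc(O)cc1`: > 100000 nM, a limit of the assay
Compound 2 `CN(c1ccc(Cl)cc1)S(=O)(=O)C1CC2OC1C(c1ccc(NC(=O)CCCCCCC(=O)O)cc1)=C2c1ccc(O)cc1`: 72100 nM
Compound 3 `CCN(c1ccccc1)S(=O)(=O)C1CC2OC1C(c1ccc(NC(=O)CCCCCCC(=O)O)cc1)=C2c1ccc(O)cc1`: > 100000 nM, a limit of the assay

The measurements come from a functional assay on DU-145 cells (Homo sapiens) for antiproliferative activity, read by MTT assay, with a stated time of 72 h; a lower number here means a stronger inhibitor, a higher number a weaker inhibitor. Compound 3 has no number here, only the limit > 100000 nM. This is the limit of > 100000 nM in this assay, at which 2 of the 3 values shown sit.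

Compound 4 `CCN(c1ccc(C)cc1)S(=O)(=O)C1CC2OC1C(c1ccc(NC(=O)CCCCCCC(=O)O)cc1)=C2c1ccc(O)cc1` differs from compound 3 by one change: methyl in place of hydrogen on an aromatic carbon. It is methyl in place of hydrogen on an aromatic carbon, para to a large group, turning ethyl(phenyl)amino into ethyl(4-methylphenyl)amino.

The nearest measured change is also a replacement of hydrogen on an aromatic carbon, here by chloro: an at least 1.3-fold lower number from compound 1 to compound 2 (0.14 log units; that floor lies within the scatter). The comparison an at least 1.3-fold higher number from compound 2 to compound 3 (0.14 log units; that floor lies within the scatter) is equally small, and a step that the two limits leave unreadable from compound 1 to compound 3 gives no size at all. None of these steps therefore supports a change beyond the scatter, so no clear step is expected in this assay, and compound 4 is expected to stay close to the limit.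

The expected change is an at least 1.1-fold lower number from compound 3 to compound 4 (0.07 log units; that floor lies within the scatter). For compound 4 the estimated value is 85000 nM, with an expected range from 45000 nM to 130000 nM.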

Compound 4, half-maximal inhibitory concentration: 53500 nM
Estimate against measurement, compound 4: 1.6-fold (0.20 log units) above; low and high end bracket the measured number.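

In this assay, methyl in place of hydrogen on an aromatic carbon, para to a large group, gives compound 4 a measured number where compound 3 has only a limit, with an at least 1.8-fold lower number from compound 3 to compound 4 (0.27 log units; that floor lies within the scatter). That step can be read only as a floor, because compound 3 sits at a limit of the assay: the limit of > 100000 nM in this assay, at which 2 of the 4 values shown sit. The two compounds with a substituent on this ring do not separate, with a 1.3-fold lower number from compound 2 to compound 4 (0.13 log units; within the scatter), while the full change on the sulfonyl sulfur reads an at least 1.8-fold lower number from compound 1 to compound 4 (0.27 log units; that floor lies within the scatter).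

The compounds shown leave open whether a methoxy or a trifluoromethyl group at this place would carry the number clearly beyond the scatter. They also leave open how a chloro group would read alongside the ethyl on the sulfonamide nitrogen.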